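A few compounds are considered here, and "the series" means these few. Any claim that something is new, unique, unknown or untested is made for them only; others in the source may bear on it.

Measured so far:
compound 1, `CC[C@H](CCn1cncn1)c1ccccc1`: 97.7 ug/mL
compound 2, `CC[C@@H](CCn1cncn1)c1ccc(F)cc1`: 90.3 ug/mL
compound 3, `CCC[C@H](CCn1cncn1)c1ccccc1`: 58.4 ug/mL

In an ADME assay on HEp-2 cells (Homo sapiens) for cytotoxicity, read by MTT assay, with a stated time of 3 days (on this read-out lower numbers stand for higher toxicity in this test and higher numbers for lower toxicity in this test), compound 3 gives the lowest of the three numbers, yet its distance to compound 2 and to compound 1 is within the scatter, so no order among them is established. Compound 4, `CCC[C@H](CCn1cncn1)c1ccc(C)cc1`, differs from compound 3 by methyl in place of hydrogen on an aromatic carbon. Within the data shown here, the only measured step, a 1.7-fold lower number from compound 1 to compound 3 (0.22 log units; within the scatter), concerns a methyl on the saturated chain, not on the ring, and was within the scatter; no measured pair shows a substituent added to the aromatic carbon on an otherwise unchanged compound, so no direct precedent exists. The expected step is a 1.3-fold lower number from compound 3 to compound 4 (0.11 log units; within the scatter), not beyond the scatter. Compound 4 is therefore estimated at 45 ug/mL, between 18 ug/mL and 110 ug/mL.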

Compound 4, half-maximal cytotoxic concentration: 45.7 ug/mL
Beside the measured number, compound 4's estimate is 1.0-fold (0.01 log units) below it; the range from low to high includes it.
By their numbers in this assay, from the lowest: compounds 4, 3, 2 and 1 (each within the scatter of the next, the first and the last beyond it).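

In this assay, the ring position para to a large group now has its first measured single change: methyl in place of hydrogen on an aromatic carbon gives a 1.3-fold lower number from compound 3 to compound 4 (0.11 log units; within the scatter). This step lies within the scatter, so the methyl establishes no change at this position. No measurement available here explains the result.

Still open, from the compounds shown here alone, is whether an amine or a carboxylic acid on the same aromatic carbon would move the number beyond the scatter. Also open, going by these compounds, is whether methyl there gives a similar step on the core of compound 1.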